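The source may hold more compounds than are shown below. What is called first, only, known or untested is meant among the compounds shown, and "the series" means these compounds.

Measured so far in an assay on RBL-1 cells for inhibition of Polyunsaturated fatty acid 5-lipoxygenase (Rattus norvegicus); a lower number here means a stronger inhibitor, a higher number a weaker inhibitor:

compound 1 `O=C(/C=C/c1ccc(O)c(O)c1)c1cccc(O)c1`, 4.2 nM
compound 2 `O=C(/C=C/c1ccc(O)c(O)c1)c1ccc(O)cc1`, 4 nM
compound 3 `O=C(/C=C/c1ccc(O)c(O)c1)c1ccccc1-c1cccnc1`, 210 nM

Compound 2 has the lowest number of the three in this assay. Its nearest neighbour is compound 1, whose number lies within the scatter, so the two cannot be ordered. Compound 3 stands far away at a much higher number, beyond the scatter.

Compound 4 `Cc1ccc(C(=O)/C=C/c2ccc(O)c(O)c2)cc1` has not yet been measured. It differs from compound 2 in one place: methyl in place of hydroxy on an aromatic carbon. For the measured compounds named here, no measured pair shows this change, so its effect can only be guessed. Going by the values given here, the one compound without a hydroxy on that ring, compound 3, gives 210 nM, but it also carries a different group, so it says little about the hydroxy alone. The account expects a modest rise in number from compound 2 to compound 4, a 3.0-fold higher number from compound 2 to compound 4 (0.48 log units; beyond the scatter). Compound 4 is therefore estimated at 12 nM, with a range from 3 nM to 50 nM.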

Compound 4, half-maximal inhibitory concentration: 76 nM
Beside the measured number, compound 4's estimate is 6.3-fold (0.80 log units) below it; measured number outside the range, above it.
By their numbers in this assay, from the lowest: compounds 2 and 1 (each within the scatter of the next); then compound 4; then compound 3.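

In this assay the hydroxy on this aromatic carbon, para to a large group, proves not to be interchangeable with a methyl of the same heavy-atom count: the swap gives a 19-fold higher number from compound 2 to compound 4 (1.28 log units; beyond the scatter). For the compounds shown here, this is the first step that isolates a single place, and it shows that this position is sensitive to what sits on it, a point compound 3 could not settle because it differs in more than one place. The change removes one hydrogen-bond donor and one acceptor, but nothing measured here tells why the number rises.

Going by these compounds, whether an amine or a methoxy on this carbon would stay close to compound 2 or move toward compound 4 remains open. Also open, on these data alone, is whether the same methyl swap would cost as much at the hydroxy of compound 1 .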